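The source may hold more compounds than are shown below. What is called first, only, known or untested is meant among the compounds shown, and "the series" means these compounds.

Compound 1 `CC(=O)N1CCC(C[C@@H](c2nc3cc(F)ccc3n2C)N2C(=O)CN(c3ccc(Oc4ccccc4)cc3)C2=O)CC1`: 8300 nM
Compound 2 `CC(C)C(=O)N1CCC(C[C@@H](c2nc3ccccc3n2C)N2C(=O)CN(c3ccc(Oc4ccccc4)cc3)C2=O)CC1`: 38 nM

Both were tested in an assay on isolated protein for antagonist activity at Bile acid receptor (Homo sapiens), read by TR-FRET and LanthaScreen; a higher number here means a weaker inhibitor, a lower number a stronger inhibitor. Compound 2 gives the lower of the two numbers, and compound 1 a far higher one, but these two compounds differ in two places, so that gap cannot be split into parts. Compound 3 `CC(C)C(=O)N1CCC(C[C@@H](c2nc3cc(F)ccc3n2C)N2C(=O)CN(c3ccc(Oc4ccccc4)cc3)C2=O)CC1` is compound 2 with fluoro in place of hydrogen on an aromatic carbon; it thus carries the fluoro of compound 1 while keeping everything else of compound 2. A step toward a higher number, of moderate size, is expected, a 7.9-fold higher number from compound 2 to compound 3 (0.90 log units; beyond the scatter), because compound 1 gives 8300 nM. Compound 3 is therefore estimated at 300 nM, within a range from 60 nM to 2000 nM.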

Compound 3, half-maximal inhibitory concentration: 340 nM
For compound 3 the middle estimate is 1.1-fold (0.05 log units) below the measured one; measured number inside the range.
By their numbers in this assay, from the lowest: compound 2; then compound 3; then compound 1.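

In this assay, within the data shown here, fluoro in place of hydrogen on this aromatic carbon brings an 8.9-fold higher number from compound 2 to compound 3 (0.95 log units; beyond the scatter) and so weakens inhibition when it is the only change. With the fluoro kept, isopropyl in place of methyl on the carbonyl carbon brings a 24-fold lower number from compound 1 to compound 3 (1.39 log units; beyond the scatter) and so restores much of the lost strength, which shows that each place counts on its own. Nothing available explains either step. Still open, on these data alone, is whether chloro or methoxy on the same aromatic carbon would be tolerated, and whether cyclopropyl or tert-butyl on the carbonyl carbon would give stronger inhibition than isopropyl.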